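The compounds below may be only part of what the source reports. "The series", "measured", "known", "first", "only" and "open" are said of these compounds alone.

Of the compounds shown here, three built on one shared core have been tested in a functional assay on HeLa cells (Homo sapiens) for antiproliferative activity, with a stated time of 24 h; on this read-out higher numbers stand for weaker inhibition and lower numbers for stronger inhibition. Compound 1 `NC(=O)c1c(NC(=O)c2ccccc2Cl)sc2c1CCN(C(=S)Nc1ccccc1F)C2` gives 28700 nM. Compound 2 `NC(=O)c1c(NC(=O)c2ccccc2Br)sc2c1CCN(C(=S)Nc1ccccc1Cl)C2` gives 46900 nM. Compound 3 `Cc1ccccc1C(=O)Nc1sc2c(c1C(N)=O)CCN(C(=S)Nc1ccccc1Cl)C2` gives 35300 nM. Among the measured compounds shown here, compound 2 has the highest of these three numbers, but the only one-place step that has been measured, a 1.3-fold lower number from compound 2 to compound 3 (0.12 log units; within the scatter), is within the scatter, and the gap between compound 1 and compound 2 is within the scatter as well.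

Compound 4 `NC(=O)c1c(NC(=O)c2ccccc2Br)sc2c1CCN(C(=S)Nc1ccccc1F)C2` has not yet been measured. It differs from compound 2 in one place: fluoro in place of chloro on an aromatic carbon. For the measured compounds named here, no measured step covers this change on its own. Going by the values given here, compound 1 carries the fluoro at this place but differs from compound 2 in a second ring too, and the single measured step, which sits on the other ring, moved the number by an amount within the scatter. On this basis the step of a 1.2-fold lower number from compound 2 to compound 4 (0.09 log units; within the scatter) is expected to stay within the scatter. Compound 4 is therefore estimated at 38000 nM, with a range from 15000 nM to 95000 nM.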

Compound 4, half-maximal inhibitory concentration: > 50000 nM
Compound 4 was reported as a limit (the forecaster's own chance of this, stated with the estimate: 10%); middle value at least 1.3-fold (0.11 log units) from the limit.
By their numbers in this assay, from the lowest: compounds 1, 3 and 2 (each within the scatter of the next). At a limit, above all of these: compound 4.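

In this assay, compound 4 is reported as a limit and not as a number: the limit of > 50000 nM in this assay, at which 1 of the 4 values shown sits. For fluoro in place of chloro at this place, ortho to a large group, the result is an at least 1.0-fold higher number from compound 2 to compound 4 (0.02 log units; that floor lies within the scatter), and for bromo in place of chloro on the other ring, it is an at least 1.7-fold higher number from compound 1 to compound 4 (0.24 log units; that floor lies within the scatter). Among the compounds shown here, this is the first direct reading of the fluoro and chloro exchange with the rest of the molecule unchanged, and neither step brings a lower number, although both floors leave their true sizes unknown.

Going by these compounds, how far the number of compound 4 really lies from those of compound 1 and compound 2 remains open. The compounds shown also leave open how a methoxy group or an amine at this place on the ring would read.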